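The compounds below may be only part of what the source reports. "The series", "measured", "known", "first", "only" and "open" are said of these compounds alone.

In a functional assay on HeLa cells (Homo sapiens) for antiproliferative activity, read by MTT assay, with a stated time of 48 h (on this read-out higher numbers stand for weaker inhibition and lower numbers for stronger inhibition), compound 1, with the structure `CC1CN(c2c(F)c(N)c3c(=O)c(C(=O)O)cn(C4CC4)c3c2F)CC(C)N1CN1C(=O)C(=O)c2ccccc21`, reaches only the limit of the assay, reported as >= 18.3 ug/mL. Compound 2, with the structure `CC1CN(c2c(F)c(N)c3c(=O)c(C(=O)O)cn(C4CC4)c3c2F)CC(C)N1CN1C(=O)/C(=N\c2ccc(S(=O)(=O)Nc3ncccn3)cc2)c2ccccc21`, is likewise reported in this assay only as a limit, >= 18.3 ug/mL. So compound 2 stands at the edge of what the assay can resolve, and it stands there together with the other measured compound: the limit of >= 18.3 ug/mL in this assay, at which 2 of the 2 values shown sit. No step between measured compounds is available, and nothing among the shown values points to a difference between compound 1 and compound 2 beyond the limit itself.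

Compound 3, with the structure `COc1ncnc(NS(=O)(=O)c2ccc(/N=C3\C(=O)N(CN4C(C)CN(c5c(F)c(N)c6c(=O)c(C(=O)O)cn(C7CC7)c6c5F)CC4C)c4ccccc43)cc2)c1OC`, has not yet been measured in this assay. It differs from compound 2 in one place: 5,6-dimethoxypyrimidin-4-yl in place of pyrimidin-2-yl on a sulfonamide nitrogen. Among the measured compounds shown here, since the only evidence is a shared limit, no direction for this change can be read from the data. The step from compound 2 to compound 3 in this assay is expected to be a step that the limit leaves unreadable from compound 2 to compound 3, that is, none beyond the scatter. Compound 3 is therefore expected to give about 25 ug/mL, within a range from 15 ug/mL to 60 ug/mL, most likely again reported as a limit.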

Compound 3, half-maximal inhibitory concentration: 18.3 ug/mL
Estimate against measurement, compound 3: 1.4-fold (0.14 log units) above; measured number inside the range.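

In this assay, the change to 5,6-dimethoxypyrimidin-4-yl in place of pyrimidin-2-yl on a sulfonamide nitrogen gives a number no higher from compound 2 to compound 3 (the limit leaves the size open). Among the compounds shown here, at this position, compound 3 gives the only value shown that is a number rather than a limit, 18.3 ug/mL, so the larger group, with its two added oxygen atoms, comes with a readable result. Even so, the size of the step stays open because the value of compound 2 is only a limit, and the number for compound 3 coincides with the figure of that limit: the limit of >= 18.3 ug/mL in this assay, at which 2 of the 3 values shown sit.

The compounds shown therefore leave open whether changing the group on the sulfonamide nitrogen can move the result in this assay at all, since no value lies clearly apart from this figure. They also do not tell whether an amine or a longer alkoxy chain on the 5,6-dimethoxypyrimidin-4-yl group, or a simple phenyl ring in its place, would give a value distinct from that of compound 3.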